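This account rests on a few compounds, and the source may have more. Where it says the series, first, only, none or still open, it means among the compounds named here.

Measured so far in an ADME assay on HEL cells (Homo sapiens) for cytotoxicity; a higher number here means that more compound is tolerated, a lower number that less compound is tolerated:
- compound 1 `O=C(COc1cccc2ccccc12)N/N=C/c1ccc(Cl)cc1`: 100 ug/mL
- compound 2 `C/C(=N\NC(=O)COc1cccc2ccccc12)c1cccc([N+](=O)[O-])c1`: 20 ug/mL
- compound 3 `O=C(COc1cccc2ccccc12)N/N=C/c1ccccc1Br`: >= 20 ug/mL (a limit of the assay, not a number)

Compound 1 holds the highest of the two numbers given. The nearest number is that of compound 2, which sits well below it, beyond the scatter of this assay. For compound 3 only a limit is given; the step from compound 1 to compound 3 is therefore a step that the limit leaves unreadable from compound 1 to compound 3, and the limit of >= 20 ug/mL in this assay, at which 1 of the 3 values shown sits, marks the limit at which that value sits.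

Compound 4 `O=C(COc1cccc2ccccc12)N/N=C/c1ccc([N+](=O)[O-])cc1` has not yet been measured. It differs from compound 1 by nitro in place of chloro on an aromatic carbon. Going by the values given here, no measured step follows this change alone. Compound 2, the only measured compound that also carries a nitro group, differs from compound 1 in more than one place, so its value can only be set beside that of compound 1: it lies at the lower end of the numbers shown. Taking that as the only guide, a drop in tolerated concentration is expected, of roughly a 2.0-fold lower number from compound 1 to compound 4 (0.30 log units; within the scatter). Compound 4 is therefore estimated at 50 ug/mL, with a range from 20 ug/mL to 100 ug/mL.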

Compound 4, minimum cytotoxic concentration: 20 ug/mL
For compound 4 the middle estimate is 2.5-fold (0.40 log units) above the measured one; the measured number falls inside the stated range.
By their numbers in this assay, from the lowest: compounds 2 and 4 (each within the scatter of the next); then compound 1.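

Nitro in place of chloro on an aromatic carbon, para to a large group, gives a 5.0-fold lower number from compound 1 to compound 4 (0.70 log units; beyond the scatter) in this assay. Going by these compounds alone, this is the first single-place change that can be read, and it shows that this aromatic carbon is not indifferent to the group it carries in this assay. Compound 2 also carries nitro but differs from compound 1 in more than one place, so it could not tie the lower number to this swap alone.

Compound 3 carries only a limit of the assay, so its step from compound 1 cannot be read: the limit of >= 20 ug/mL in this assay, at which 1 of the 4 values shown sits. Within the data shown here, with chloro and nitro the only groups read at this position, one step makes no trend, and an amine or a carboxylic acid on this aromatic carbon remains open.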